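A few compounds are considered here, and "the series" means these few. Any claim that something is new, unique, unknown or untested is made for them only; others in the source may bear on it.

Working notes on the benzyl thiourea series.

Three members have been measured in a functional assay on A549 cells (Homo sapiens) for cytotoxicity, read by MTT assay; on this read-out lower numbers stand for stronger inhibition and higher numbers for weaker inhibition. Compound 1 `CC(C)[C@H](NC(=S)NCc1ccccc1)c1nc2ccccc2[nH]1` gives 56100 nM in this assay. Compound 2 `CC(C)C[C@H](NC(=S)NCc1ccccc1)c1nc2ccccc2[nH]1` gives 75700 nM in this assay; the step of a 1.3-fold higher number from compound 1 to compound 2 (0.13 log units; within the scatter) shows that isobutyl in place of isopropyl on the saturated chain carbon leaves the number essentially unchanged. Compound 3 `C[C@@H](NC(=S)NCc1ccccc1)c1nc2ccccc2[nH]1` gives 18700 nM in this assay and stands lowest of the three numbers, with its gap to compound 1 and its larger gap to compound 2 both beyond the scatter, so the methyl-bearing member is the one with the strongest inhibition among the measured set.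

Compound 4 `C[C@H](NC(=S)NCc1ccccc1)c1nc2ccccc2[nH]1` has not yet been measured. Relative to compound 3: the two compounds have the same atoms and bonds and differ only in configuration as drawn: 1 of 1 stereo elements differ; a stereocentre at a saturated chain carbon is drawn R in compound 3 and S in compound 4. Going by the values given here, none of the measured steps bears on a change of configuration; the single step available, from compound 1 to compound 2, concerns the size of the alkyl group and stayed within the scatter, so it gives no guide here. The series therefore offers no basis to expect a shift in either direction in this assay, and a step no larger than the scatter is the working assumption, with the range kept wide to allow for an unseen difference between the two configurations. The estimated step is a 1.5-fold higher number from compound 3 to compound 4 (0.18 log units; within the scatter). Compound 4 is accordingly expected to give about 28000 nM in this assay, within a range from 9000 nM to 90000 nM.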

Compound 4, half-maximal inhibitory concentration: "not active" (no number reported)
Nothing numeric was reported for compound 4; the estimate stays without a comparison.
By their numbers in this assay, from the lowest: compound 3; then compounds 1 and 2 (each within the scatter of the next).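

In this assay compound 4 is reported as "not active" without a number, so no step can be read against compound 3 at 18700 nM or against any other member of the series. The compounds shown leave open how large a difference in this read-out goes with what separates the pair: the fact that compounds 3 and 4 differ only in the configuration as drawn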